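A Chlorophenyl Alkyne Variant of a Weak Binder

The compounds below may be only part of what the source reports. "The series", "measured", "known", "first", "only" and "open" are said of these compounds alone.

Compound 1 `CNC(=O)c1ccc(C#Cc2ccccc2)nc1` — 15000 nM
Compound 2 `Cc1ccccc1C#Cc1ccc2c(n1)CCN(C)C2=O` — > 32000 nM

In an assay on HEK293 cells for displacement of a labelled ligand from metabotropic glutamate receptor 5 (Homo sapiens), with a stated time of 2 h (a higher number here means a weaker inhibitor, a lower number a stronger inhibitor), compound 1 gives 15000 nM. Compound 2, built on a different core, reaches only a limit in this assay, > 32000 nM. Where compound 2 stands is therefore fixed from one side only: the limit of > 32000 nM in this assay, at which 1 of the 2 values shown sits, so its inhibition constant is not known as a number. Within the data shown here, no step between compound 1 and compound 2 is computed here, since they differ in more than one place; their two values show only that compound 1 gives a number and compound 2 does not.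

Compound 3 `CN1CCc2nc(C#Cc3cccc(Cl)c3)ccc2C1=O` differs from compound 2 by 3-chlorophenyl in place of 2-methylphenyl on a triple-bonded carbon. Among the measured compounds shown here, no measured step bears on this change, so any expectation rests on the limit of compound 2 alone. The step in this assay from compound 2 to compound 3 is estimated as an at least 3.2-fold lower number from compound 2 to compound 3 (0.50 log units; beyond the scatter), toward a stronger inhibitor, though a step of none beyond the scatter remains possible. Compound 3 is expected to give about 10000 nM in this assay, within 1000 nM to 32000 nM, with a real chance that only a limit is reported again.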

Compound 3, inhibition constant: 250 nM
Compound 3: middle estimate off by 40-fold (1.60 log units), on the high side, outside the stated range (below it).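

In this assay, replacing 2-methylphenyl with 3-chlorophenyl on the triple-bonded carbon gives an at least 120-fold lower number from compound 2 to compound 3 (2.10 log units; beyond the scatter). Among these compounds, this shows that the group at this position can decide whether the shared core gives a measurable inhibition constant or only a limit, something the earlier compounds could not show. The two groups have the same counts of heavy atoms, hydrogen-bond donors and hydrogen-bond acceptors, and neither carries a net charge, so those counts do not account for the difference, and the full size of the step stays unfixed, as compound 2 is held only by a limit: the limit of > 32000 nM in this assay, at which 1 of the 3 values shown sits.

As far as these compounds go, whether a 3-methylphenyl or a 2-chlorophenyl on the shared core would behave like compound 2 or like compound 3 remains open, so the step cannot yet be divided between the chlorine itself and where the group sits on the ring. Also open, from the compounds shown here alone, is how a 3-fluorophenyl, a 3-methoxyphenyl or a pyridine ring would fare on this triple-bonded carbon, and whether 3-chlorophenyl would have a similar effect on the core of compound 1.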